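Swapping 4-methylbenzyl for 4-bromophenyl on a sulfonyl sulfur

A few compounds are considered here, and "the series" means these few. Any claim that something is new, unique, unknown or untested is made for them only; others in the source may bear on it.

Going by the values given here, in a functional assay on DU-145 cells (Homo sapiens) for inhibition, read by trypan blue exclusion, with a stated time of 96 h (a lower number here means a stronger inhibitor of growth, a higher number a weaker inhibitor of growth), compound 1 `Cc1ccc(CS(=O)(=O)/C(=C/c2ccccc2OCc2ccccc2)C(=O)c2ccc(Cl)cc2)cc1` gives 1000 nM, the only true number so far. Compound 2 `Nc1c(Br)cc(Br)cc1/C=C(/Sc1ccc(Br)cc1)C(=O)c1ccc(Br)cc1` is recorded only as a limit, > 100000 nM, in this assay. Compound 3 `O=C(/C(=C\c1ccccc1OCc1ccccc1)S(=O)(=O)c1ccc(Br)cc1)c1ccc(Cl)cc1` has not yet been measured. It keeps the core of compound 1 and changes in one place, with 4-bromophenyl in place of 4-methylbenzyl on a sulfonyl sulfur. Among the compounds with values here, no measured pair of compounds shows what such a change does, so the expectation is anchored on compound 1 at 1000 nM and stays loose. A modest weakening of growth inhibition, somewhat beyond the usual scatter, is expected, an estimated step of a 3.0-fold higher number from compound 1 to compound 3 (0.48 log units; beyond the scatter). For compound 3 the expected value in this assay is 3000 nM, with an estimated range from 500 nM to 30000 nM.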

Compound 3, concentration for 50% growth inhibition: 1000 nM
The estimate for compound 3 lay 3.0-fold (0.48 log units) above the measured number, within the range that was stated.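

In this assay, going by these compounds alone, the exchange gives no change at the digits printed from compound 1 to compound 3 (within the scatter) and so supplies the first measured pair for a change on this sulfonyl sulfur. It shows that, on the shared core, growth inhibition holds with either 4-methylbenzyl or 4-bromophenyl on that sulfur, two groups that each carry one six-membered aromatic ring of carbon only. Nothing measured here bears on why the exchange leaves the number as it stands.

This single pair swaps the methyl for bromine and removes the chain carbon in one step, so the two changes cannot be told apart. From the compounds shown here alone, whether a ring bearing an amine or a carboxylic acid, or a longer chain, would be accepted in place of 4-methylbenzyl on a sulfonyl sulfur stays open.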